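A few compounds are considered here, and "the series" means these few. Any claim that something is new, unique, unknown or untested is made for them only; others in the source may bear on it.

In an assay on THP-1 cells for displacement of a labelled ligand from C-C chemokine receptor type 1 (Homo sapiens) (on this read-out higher numbers stand for weaker inhibition and lower numbers for stronger inhibition), compound 1 `CC(C)CCC(=O)N[C@@H](C(=O)N1CCC(c2ccc(Cl)cc2)CC1)C(C)C` gives 26 nM, the lowest of the three numbers recorded. Compound 3 `CC(C)C(NC(=O)c1ccccc1)C(=O)N1CCN(c2ccc(Cl)c(Cl)c2)CC1` stands nearest to it with 375 nM, a gap beyond the scatter, and compound 2 `CC(C)C(NC(=O)OCc1ccccc1)C(=O)N1CCC(c2ccc(Cl)cc2)CC1` lies furthest away with 1080 nM. The next step leads from compound 1 to compound 4 `Cc1cccc(CCC(=O)N[C@@H](C(=O)N2CCC(c3ccc(Cl)cc3)CC2)C(C)C)c1`, which has not yet been measured. The change is 3-methylphenyl in place of isopropyl on a saturated chain carbon, two bonds along the chain from a carbonyl carbon, with the shared core otherwise untouched. Among the compounds with values here, no pair of measured compounds differs in this place alone, so there is no directly comparable step to draw on. The step is expected to be small, a 1.5-fold higher number from compound 1 to compound 4 (0.19 log units; within the scatter), in no direction clearly beyond the scatter. Compound 4 is therefore estimated in this assay at 40 nM, between 10 nM and 160 nM.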

Compound 4, half-maximal inhibitory concentration: 22 nM
Compound 4: the middle estimate sits 1.8-fold (0.26 log units) above what was measured; the range from low to high includes it.
By their numbers in this assay, from the lowest: compounds 4 and 1 (each within the scatter of the next); then compound 3; then compound 2.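

In this assay, 3-methylphenyl in place of isopropyl on a saturated chain carbon, two bonds along the chain from a carbonyl carbon, gives a 1.2-fold lower number from compound 1 to compound 4 (0.07 log units; within the scatter) and so shows no change beyond the scatter. This first readable step at this position shows that an aromatic ring of 7 heavy atoms can replace the isopropyl group of 3 heavy atoms without a measurable shift in the number. No available evidence explains this result. As far as these compounds go, whether an amine, a carboxylic acid or a longer chain at this place would leave the number equally unchanged remains open.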